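A few compounds are considered here, and "the series" means these few. Any claim that something is new, unique, unknown or untested is made for them only; others in the source may bear on it.

Compound 1 `CCCC1Nc2ccc(C(C)C)cc2C(=O)N1Cc1ccc(-c2ccccc2-c2nn[nH]n2)cc1` gives 50 nM in an assay on adrenal cortex for inhibition of angiotensinogen (Rattus norvegicus); on this read-out higher numbers stand for weaker inhibition and lower numbers for stronger inhibition.
Compound 2 `CCCC1Nc2ccccc2C(=O)N1Cc1ccc(-c2ccccc2-c2nn[nH]n2)cc1` gives 540 nM in this assay.

Compound 1 stands lowest of the two numbers. For the measured compounds named here, the only measured step, an 11-fold higher number from compound 1 to compound 2 (1.03 log units; beyond the scatter), comes from hydrogen in place of isopropyl on an aromatic carbon. Compound 3 `CCC1Nc2ccc(C(C)C)cc2C(=O)N1Cc1ccc(-c2ccccc2-c2nn[nH]n2)cc1` differs from compound 1 elsewhere: hydrogen in place of methyl on a saturated chain carbon, two bonds along the chain from a saturated ring carbon. Going by the values given here, no measured step touches this chain, so the known step does not bear on it, and no change beyond the scatter is expected, with a slight weakening as the likelier lean. The estimate for compound 3 is 80 nM, within 30 nM to 250 nM. That corresponds to an expected step of a 1.6-fold higher number from compound 1 to compound 3 (0.20 log units; within the scatter).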

Compound 3, half-maximal inhibitory concentration: 90 nM
Estimate against measurement, compound 3: 1.1-fold (0.05 log units) below; the measured number falls inside the stated range.
By their numbers in this assay, from the lowest: compounds 1 and 3 (each within the scatter of the next); then compound 2.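

Going from propyl to ethyl gives a 1.8-fold higher number from compound 1 to compound 3 (0.26 log units; within the scatter), so in this assay this chain can lose its end methyl with no change that stands out from the scatter. The isopropyl group on the aromatic carbon behaves differently: replacing it with hydrogen gives an 11-fold higher number from compound 1 to compound 2 (1.03 log units; beyond the scatter). No available evidence gives a cause for either result. The compounds shown leave open how far this tolerance extends. A shorter methyl, a longer butyl chain or an amine at the chain's end could each hold the number or shift it.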